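Taking the Chloro off Compound 1

The compounds below may be only part of what the source reports. "The series", "measured", "known", "first", "only" and "open" are said of these compounds alone.

In a functional assay on IMR-32 cells (Homo sapiens) for cytotoxicity, read by sulforhodamine B assay, with a stated time of 48 h (a higher number here means a weaker inhibitor, a lower number a stronger inhibitor), compound 1 `C=CCOc1c(Cl)cccc1C(=O)c1cccnc1` gives 94000 nM. Compound 3 `C=CCOc1c(Cl)cc(Cl)cc1C(=O)c1cccnc1` gives 52000 nM, which is within the scatter of compound 1, while compound 2 `O=C(c1cccnc1)c1cccc(Cl)c1O` gives 26000 nM. Compound 1 therefore sits level with compound 3 and apart from compound 2.

Compound 4 `C=CCOc1ccccc1C(=O)c1cccnc1` is compound 1 with a single change: hydrogen in place of chloro on an aromatic carbon. Going by the values given here, no measured step makes exactly this change. The nearest is a 1.8-fold lower number from compound 1 to compound 3 (0.26 log units; within the scatter), where a chloro replaces hydrogen on a different aromatic carbon, so it runs the opposite way and in another place. The step of a 3.6-fold lower number from compound 1 to compound 2 (0.56 log units; beyond the scatter) is larger, but it changes the allyl group on oxygen and says little about a chloro. Among the compounds with values here, with compound 3 as the only guide, a small change is expected, with no clear direction. The expected result is a 1.1-fold higher number from compound 1 to compound 4 (0.03 log units; within the scatter), which would not stand out from the scatter. The estimated value for compound 4 is 100000 nM, with an expected range from 50000 nM to 200000 nM.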

Compound 4, half-maximal inhibitory concentration: 44000 nM
The estimate for compound 4 lay 2.3-fold (0.36 log units) above the measured number; measured number below the stated range.
By their numbers in this assay, from the lowest: compounds 2, 4, 3 and 1 (each within the scatter of the next, the first and the last beyond it).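

In this assay, the chloro ortho to an allyloxy group turns out to count: taking it off gives a 2.1-fold lower number from compound 1 to compound 4 (0.33 log units; beyond the scatter), a modest gain in strength. Going by these compounds alone, until now the only chloro change was one added on a different aromatic carbon, a 1.8-fold lower number from compound 1 to compound 3 (0.26 log units; within the scatter), which did not rise above the scatter and so could not show that a chloro on this ring affects the number at all. Nothing available explains why removing this chloro moves the number.

Going by these compounds, only chloro and hydrogen are seen on this carbon, so it remains open how a fluoro, a methyl or a methoxy group there would compare. On these data alone, it is also open whether losing the chloro has the same effect in compound 2, which carries a hydroxyl in place of the allyloxy group.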